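Amide nitrogen variation in the hydroxy-oxo series

A few compounds are considered here, and "the series" means these few. Any claim that something is new, unique, unknown or untested is made for them only; others in the source may bear on it.

Compound 3 `O=C(NCc1ccccc1)c1c(O)c2cccnc2n(-c2ccccc2)c1=O` stands second highest of the three compounds measured in a functional assay on the whole organism for inhibition, with Rattus norvegicus as the target, read by paw edema, at a dose of 100 mg/kg by the oral route (on this read-out lower numbers stand for less inhibition and higher numbers for more inhibition at the one dose given (going by the name of the read-out)), where compound 3 gives 1.6%. Compound 1 `CCOC(=O)c1c(O)c2cccnc2n(-c2ccccc2)c1=O`, carrying ethoxy on the carbonyl carbon, gives 23.5%, and compound 2 `O=C(Nc1ccccn1)c1c(O)c2cccnc2n(-c2ccccc2)c1=O`, with (pyridin-2-yl)amino in that place, gives -13.5%. Both amides sit well below the ester: a number 37 percentage points lower from compound 1 to compound 2 (beyond the scatter) and a number 21.9 percentage points lower from compound 1 to compound 3 (beyond the scatter). Between the two amides, a number 15.1 percentage points higher from compound 2 to compound 3 (beyond the scatter).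

Compound 4 `O=C(NN1CCOCC1)c1c(O)c2cccnc2n(-c2ccccc2)c1=O` differs from compound 3 only at the amide-type nitrogen: morpholin-4-yl in place of benzyl on an amide-type nitrogen. Within the data shown here, the single measured step at this place is the one from compound 2 to compound 3, in which pyridin-2-yl gave way to benzyl and the number rose by a modest amount. Compound 4 runs the other way, replacing the ring of carbon only with a ring holding two hetero atoms, so a modest downward step from compound 3 of roughly the size of a number 15.1 percentage points higher from compound 2 to compound 3 (beyond the scatter) is the nearest guide, with compound 2 marking where such an amide has already landed. Compound 4 is therefore expected to give about -8%, within -28% to 12%. The expected step of a number 9.6 percentage points lower from compound 3 to compound 4 (within the scatter) is modest and downward, though a result within the scatter of compound 3 cannot be excluded.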

Compound 4, a percentage reported as inhibition, in the whole organism at one dose (the size of the read-out at that dose, not a potency): -8.5%
Compound 4: middle estimate off by 0.5 percentage points, on the high side; low and high end bracket the measured number.
By their numbers in this assay, from the lowest: compounds 2 and 4 (each within the scatter of the next); then compound 3; then compound 1.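

In this assay, morpholin-4-yl on the amide-type nitrogen gives a number 10.1 percentage points lower from compound 3 to compound 4 (beyond the scatter), so benzyl now stands apart from a second group at this place, not only from pyridin-2-yl. The two heteroatom-containing rings are not separated, with a number 5 percentage points higher from compound 2 to compound 4 (within the scatter), so the change from an aromatic ring holding nitrogen to a non-aromatic ring with 2 hetero atoms makes no readable difference here, and among the three amide-type groups shown only benzyl differs from the others beyond the scatter. The ester also keeps its place above this third amide, with a number 32 percentage points lower from compound 1 to compound 4 (beyond the scatter), which extends to all three amide-type compounds the gap from ethoxy on a carbonyl carbon, and no measurement at hand accounts for any of these differences.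

Open, from the compounds shown here alone, is whether a longer chain ending in phenyl, such as 2-phenylethyl, on the amide-type nitrogen would stay with benzyl or fall with the two ring groups. Also open, going by these compounds, is how a carboxylic acid, with hydroxy in place of ethoxy on the carbonyl carbon, would compare with the ester at this one dose.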